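The source may hold more compounds than are shown below. What is called first, only, known or untested is meant among the compounds shown, and "the series" means these compounds.

Measured so far in an ADME assay on MT4 cells (Homo sapiens) for cytotoxicity, read by MTT assay; on this read-out higher numbers stand for lower toxicity in this test and lower numbers for higher toxicity in this test:
- compound 1 `O=C1c2ccccc2C(=O)N1CCOC(=S)N(C(=O)c1ccc(F)cc1F)c1ccc(Cl)cc1` gives 52000 nM
- compound 2 `O=C1c2ccccc2C(=O)N1CCOC(=S)N(C(=O)c1ccc(Cl)cc1Cl)c1ccc(Cl)cc1` gives 18000 nM
- compound 3 `O=C1c2ccccc2C(=O)N1CCOC(=S)N(C(=O)c1cc(Cl)cc(Cl)c1)c1ccc(Cl)cc1` gives 32000 nM

Compound 3 at 32000 nM cannot be told apart from either of the other two compounds. The steps that reach it, a 1.6-fold lower number from compound 1 to compound 3 (0.21 log units; within the scatter) and a 1.8-fold higher number from compound 2 to compound 3 (0.25 log units; within the scatter), both stay within the usual scatter. Only a 2.9-fold lower number from compound 1 to compound 2 (0.46 log units; beyond the scatter) goes beyond that scatter, and it is modest.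

Compound 4 `O=C1c2ccccc2C(=O)N1CCOC(=S)N(C(=O)c1ccc(Cl)c([N+](=O)[O-])c1)c1ccc(Cl)cc1` has not yet been measured. It keeps the shared core and carries 4-chloro-3-nitrophenyl in place of 3,5-dichlorophenyl on a carbonyl carbon, a swap that in full reads 4-chloro-3-nitrophenyl in place of 3,5-dichlorophenyl on a carbonyl carbon and leaves everything else untouched.

All three measured steps are swaps at this same place, so they are the best guide available. Going by the values given here, none of the measured compounds carries a nitro group, however, so this swap has no direct precedent. The largest swap so far is a 2.9-fold lower number from compound 1 to compound 2 (0.46 log units; beyond the scatter) and is only modest, so no step beyond the scatter is expected in this assay here. The expected step is a 1.2-fold lower number from compound 3 to compound 4 (0.07 log units; within the scatter) and would be too small to read as a real change. Compound 4 is estimated at 27000 nM with an expected range from 12000 nM to 60000 nM in this test.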

Compound 4, half-maximal cytotoxic concentration: 48000 nM
The estimate for compound 4 lay 1.8-fold (0.25 log units) below the measured number; measured number inside the range.
By their numbers in this assay, from the lowest: compounds 2, 3, 4 and 1 (each within the scatter of the next, the first and the last beyond it).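

In this assay, going by these compounds alone, the swap to 4-chloro-3-nitrophenyl on a carbonyl carbon puts a nitro group at this place for the first time, and it gives a 1.5-fold higher number from compound 3 to compound 4 (0.18 log units; within the scatter) and also a 1.1-fold lower number from compound 1 to compound 4 (0.03 log units; within the scatter). Within this small set, then, a group with a nitro group in place of one chlorine, and with 2 hydrogen-bond acceptors where 3,5-dichlorophenyl has 0, cannot be told apart from compound 3 or compound 1 on this read-out. The only clear separation is a 2.7-fold higher number from compound 2 to compound 4 (0.43 log units; beyond the scatter), a modest step that puts compound 4 alongside compound 1 in standing clear of compound 2, while compound 3 goes against any such split by staying within the scatter of all three; no measurement here offers an explanation for these differences.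

From the compounds shown here alone, all four compounds carry a substituted phenyl ring at this place, so it remains open whether an amine, a carboxylic acid or a saturated ring such as cyclohexyl would shift the number further. The shared core also stays fixed throughout, which leaves open what a longer chain between its oxygen and nitrogen ends would do.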